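Pyrrole for Oxane on a Shared Core: Lipophilicity

The source may report more compounds than this note shows. Statements on the series, on what has been measured and on what is new or still open speak of the compounds shown alone.

Compound 1 `O=C(Nc1ccc(C(F)(F)F)cc1)NC1CCN(C(=O)C2CCCOC2)CC1` gives 3.41.
Compound 2 `O=C(Nc1ccc(C(F)(F)F)cc1)NC1CCN(C(=O)c2cc[nH]c2)CC1` gives 3.26.
Compound 3 `O=C(Nc1ccc(OC(F)(F)F)cc1)NC1CCN(C(=O)C2CCCOC2)CC1` gives 3.42.

These three compounds were measured in a physicochemical assay for lipophilicity, read by HPLC, with a stated time of 90 min, tested at 100 uM; a higher number here means a more lipophilic compound, a lower number a more polar compound. Compound 1 and compound 3 differ only at one end of the shared core: trifluoromethoxy in place of trifluoromethyl on an aromatic carbon. That change gave a number 0.01 log units higher from compound 1 to compound 3 (within the scatter). Compound 1 and compound 2 differ at the other end: 1H-pyrrol-3-yl in place of oxan-3-yl on a carbonyl carbon. That change gave a number 0.15 log units lower from compound 1 to compound 2 (within the scatter).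

Compound 4 `O=C(Nc1ccc(OC(F)(F)F)cc1)NC1CCN(C(=O)c2cc[nH]c2)CC1` has not yet been measured in this assay. It differs from compound 3 by 1H-pyrrol-3-yl in place of oxan-3-yl on a carbonyl carbon, the same change as between compound 1 and compound 2, at the same place. Resting on the small step of a number 0.15 log units lower from compound 1 to compound 2 (within the scatter), the expected step here is a number 0.15 log units lower from compound 3 to compound 4 (within the scatter). The estimate for compound 4 in this assay is 3.27, expected to fall between 3 and 3.55.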

Compound 4, partition coefficient: 3.34
Compound 4: middle estimate off by 0.07 log units, on the low side; the range from low to high includes it.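

In this assay, putting 1H-pyrrol-3-yl in place of oxan-3-yl on the core carrying trifluoromethoxy gave a number 0.08 log units lower from compound 3 to compound 4 (within the scatter), while the same change on the core carrying trifluoromethyl gave a number 0.15 log units lower from compound 1 to compound 2 (within the scatter), and trifluoromethoxy in place of trifluoromethyl on the pyrrole-bearing compounds gave a number 0.08 log units higher from compound 2 to compound 4 (within the scatter). So the change stayed small on both cores, but each step is too small to show a real effect, and two cores cannot establish a rule for the series. Nothing available explains these numbers.

The compounds shown leave open how the same comparison would read with an amine or a carboxylic acid on the carbonyl carbon. They also leave open whether a step this small would hold on other cores.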